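Replacing a cyclic amide amine by an acyclic one

This account rests on a few compounds, and the source may have more. Where it says the series, first, only, none or still open, it means among the compounds named here.

Measured compounds in a functional assay on CHO cells for agonist activity at Melanocyte-stimulating hormone receptor (Homo sapiens), read by a luciferase reporter, with a stated time of 4 h; a lower number here means that less compound is needed, a higher number that more compound is needed for the effect:
compound 2, `O=C1C(Cc2n[nH]c3cc(F)ccc23)C(=O)N(c2ccccc2)C=CN1CC(=O)N1CCCCc2ccccc21`, 1.59 nM
compound 3, `O=C1C(Cc2n[nH]c3ccccc23)C(=O)N(c2ccccc2)C=CN1CC(=O)N1CCCCc2ccccc21`, 1.59 nM
compound 1, `COc1ccc(N(C(=O)CN2C=CN(c3cccnc3)C(=O)C(Cc3n[nH]c4cc(F)ccc34)C2=O)C(C)C)cc1`, 12.6 nM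

Compound 2 stands level with compound 3 at the lowest of the three numbers; the step of no change at the digits printed from compound 2 to compound 3 (within the scatter) shows that the fluoro on the aromatic carbon makes no difference here. Compound 1 gives the highest number, 12.6 nM, although it differs from compound 2 in several places at once, so no single step can be read from that pair.

Compound 4, `CC(C)N(C(=O)CN1C=CN(c2ccccc2)C(=O)C(Cc2n[nH]c3cc(F)ccc23)C1=O)c1ccccc1`, differs from compound 2 by a group of 10 heavy atoms (9 carbon, 1 nitrogen; one six-membered aromatic ring of carbon only) in place of a group of 11 heavy atoms (10 carbon, 1 nitrogen; one six-membered aromatic ring of carbon only, one seven-membered non-aromatic ring with 1 hetero atom), on a carbonyl carbon. Among the compounds with values here, no measured step bears directly on this change. Compound 1 also carries an isopropyl(phenyl)-type amide and sits higher than compound 2, but it differs in other positions as well. Compound 4 is therefore expected to land between these two, at an estimated 4 nM with a range from 1.5 nM to 12 nM. The expected step of a 2.5-fold higher number from compound 2 to compound 4 (0.40 log units; beyond the scatter) is modest, toward a higher number, and may fall within the scatter.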

Compound 4, half-maximal effective concentration: 186 nM
Estimate against measurement, compound 4: 47-fold (1.67 log units) below; the whole stated range lies below it.
By their numbers in this assay, from the lowest: compounds 2 and 3 (each within the scatter of the next); then compound 1; then compound 4.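

In this assay the swap of the group with one seven-membered non-aromatic ring for isopropyl(phenyl)amino, on a carbonyl carbon, brings a 120-fold higher number from compound 2 to compound 4 (2.07 log units; beyond the scatter) and so shows that the amine on this carbonyl carbon matters greatly for this read-out. Within the data shown here, the only single change available earlier, no change at the digits printed from compound 2 to compound 3 (within the scatter) on removal of the fluoro, gave no sign that the compounds could be this sensitive to a change in one place. Nothing measured among these compounds accounts for the size of this step.

The compounds shown leave open whether the large step follows from losing the ring or from the isopropyl group itself, which a group such as methyl(phenyl)amino would help separate. They also leave open whether the same step holds in the compounds without the fluoro.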